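Benzyl at the ring nitrogen of the shared core

The source may hold more compounds than are shown below. What is called first, only, known or untested is meant among the compounds shown, and "the series" means these compounds.

Compound 3 `CC(C)n1cnc2c(NCc3ccc(C(=O)Nc4ccccc4N)cc3)nc(Cl)nc21` stands highest of the three measured compounds: in a functional assay on NCI-H460 cells (Homo sapiens) for antiproliferative activity, read by CCK-8 assay, with a stated time of 72 h, tested at 8 uM (on this read-out higher numbers stand for a stronger effect at the one concentration tested and lower numbers for a weaker effect), compound 3 gives 80.5%. Compound 1 `CCC(C)n1cnc2c(NCc3ccc(C(=O)Nc4ccccc4N)cc3)nc(Cl)nc21` gives 67.7% and compound 2 `CCCCn1cnc2c(NCc3ccc(C(=O)Nc4ccccc4N)cc3)nc(Cl)nc21` gives 23.7%. Compound 4 `Nc1ccccc1NC(=O)c1ccc(CNc2nc(Cl)nc3c2ncn3Cc2ccccc2)cc1` differs from compound 3 by benzyl in place of isopropyl on an aromatic nitrogen. Among the measured compounds shown here, the steps that bear on this place are a number 56.8 percentage points higher from compound 2 to compound 3 (beyond the scatter) and a number 44 percentage points lower from compound 1 to compound 2 (beyond the scatter), both large, and a number 12.8 percentage points higher from compound 1 to compound 3 (beyond the scatter), modest; in every case the larger group at this nitrogen carried the lower number. For the measured compounds named here, no measured step introduces a ring at this position, so the size of the effect is uncertain. A decrease beyond the scatter is therefore expected, a number 35.5 percentage points lower from compound 3 to compound 4 (beyond the scatter). Compound 4 is estimated at 45%, in the range 15% to 75%.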

Compound 4, a percentage reported as inhibition, at one concentration (the size of the read-out at that concentration, not a potency): 46.4%
Estimate against measurement, compound 4: 1.4 percentage points below, and the stated range covers the measured number.
By their numbers in this assay, from the lowest: compound 2; then compound 4; then compound 1; then compound 3.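

Benzyl, the first ring at this nitrogen, gives a number 34.1 percentage points lower from compound 3 to compound 4 (beyond the scatter) and a number 21.3 percentage points lower from compound 1 to compound 4 (beyond the scatter) against the branched groups, but a number 22.7 percentage points higher from compound 2 to compound 4 (beyond the scatter) against the straight butyl chain. The earlier trend of larger group, lower number therefore does not hold for compound 4 against compound 2, and branching or a ring at this nitrogen each stand above butyl in these four compounds. Nothing measured here accounts for this order.

Open, from the compounds shown here alone, is where phenethyl, with a longer chain to the ring, or cyclohexyl, a saturated ring, would stand against benzyl and isopropyl. Also open, going by these compounds, is whether a methoxy group on the benzyl ring would move the number.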